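Working notes: from compound 3 to compound 4

The compounds below may be only part of what the source reports. "The series", "measured", "known", "first", "only" and "open" are said of these compounds alone.

In an ADME assay on microsomes from liver (Homo sapiens) for metabolic stability (on this read-out higher numbers stand for fast clearance and lower numbers for slow clearance), compound 1 `Cc1ccc2[nH]c(C(=O)N[C@H]3CN(S(=O)(=O)c4ccccc4)C[C@@H]3C(=O)NC[C@H]3CCCN3)cc2c1` reads < 3 mL.min-1.g-1, which is a limit of the assay and not a number. Compound 2 `Cc1ccc2[nH]c(C(=O)N[C@H]3CN(S(=O)(=O)c4ccccc4)C[C@@H]3C(=O)NC[C@H]3CCCN3C)cc2c1` gives 22 mL.min-1.g-1. For the measured compounds named here, the one measured step is an at least 7.3-fold higher number from compound 1 to compound 2 (0.86 log units; beyond the scatter), with methyl in place of hydrogen on an amine nitrogen in a ring. Compound 3 `O=C(N[C@H]1CN(S(=O)(=O)c2ccccc2)C[C@@H]1C(=O)N[C@H]1CCCNC1)c1cc(C2CC2)n[nH]1` reads < 3 mL.min-1.g-1, again a limit and not a number. It therefore stands at the limit of < 3 mL.min-1.g-1 in this assay, at which 2 of the 3 values shown sit.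

Compound 4 `O=C(N[C@H]1CN(S(=O)(=O)c2ccccc2)C[C@@H]1C(=O)N[C@H]1CCCNC1)c1cc(-c2ccc(Cl)cc2)on1` is still to be measured in this assay. The change is 5-(4-chlorophenyl)-1,2-oxazol-3-yl in place of 3-cyclopropyl-1H-pyrazol-5-yl on a carbonyl carbon. Going by the values given here, no measured step covers this exchange, since the methyl step from compound 1 sits at a different place. That step, an at least 7.3-fold higher number from compound 1 to compound 2 (0.86 log units; beyond the scatter), bears only indirectly, as a sign that one change in this series can carry a compound off the limit. A modest rise in the number is therefore expected, with a real chance that the result stays at the limit. The expected step is an at least 2.6-fold higher number from compound 3 to compound 4 (0.42 log units; beyond the scatter). For compound 4 the estimate is 8 mL.min-1.g-1, with an expected range from 3 mL.min-1.g-1 to 30 mL.min-1.g-1.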

Compound 4, intrinsic clearance in microsomes: < 3 mL.min-1.g-1
Compound 4: no number, only a limit; the forecaster's own chance of this, stated with the estimate: 30%; at least 2.6-fold (0.42 log units) between middle value and limit.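

Compound 3 and compound 4 both read as a limit and not a number, and the step between them cannot be read: the limit of < 3 mL.min-1.g-1 in this assay, at which 3 of the 4 values shown sit.

The compounds shown leave open whether, and how far, 5-(4-chlorophenyl)-1,2-oxazol-3-yl in place of 3-cyclopropyl-1H-pyrazol-5-yl on a carbonyl carbon shifts the read-out in this assay.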